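From diethylcarbamoyl to a 2-carboxyethyl chain

This account rests on a few compounds, and the source may have more. Where it says the series, first, only, none or still open, it means among the compounds named here.

Values in a functional assay with Oryctolagus cuniculus as the target; a higher number here means a weaker inhibitor, a lower number a stronger inhibitor:
- Compound 1 `COc1ccc(-c2nc(C(N)=O)sc2-c2ccc(OC)cc2)cc1`: > 1000 nM
- Compound 2 `COc1ccc(-c2nc(C(=O)N(C)C)sc2-c2ccc(OC)cc2)cc1`: < 100 nM
- Compound 3 `CCN(CC)C(=O)c1nc(-c2ccc(OC)cc2)c(-c2ccc(OC)cc2)s1`: < 10 nM

All three entries are limits of the assay, not numbers. From the compounds shown here alone, compound 3 stands at the limit of < 10 nM, so its true value is unknown.

Compound 4 `COc1ccc(-c2nc(CCC(=O)O)sc2-c2ccc(OC)cc2)cc1` carries 2-carboxyethyl in place of diethylcarbamoyl on an aromatic carbon.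

The closest guides are an at least 10-fold lower number from compound 1 to compound 2 (1.00 log units; beyond the scatter) and an at least 100-fold lower number from compound 1 to compound 3 (2.00 log units; beyond the scatter), both changes on a carbonyl carbon. The step that the two limits leave unreadable from compound 2 to compound 3 adds nothing further. Among the compounds with values here, no measured compound carries 2-carboxyethyl, so the guidance is indirect. The diethylamino group leaves with this change, and its arrival gave an at least 100-fold lower number from compound 1 to compound 3 (2.00 log units; beyond the scatter), so a large step to a higher number is expected in this assay.

The expected step is an at least 30-fold higher number from compound 3 to compound 4 (1.47 log units; beyond the scatter).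

For compound 4 the estimate is 300 nM, with an expected range of 30 nM to 3000 nM.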

Compound 4, half-maximal inhibitory concentration: < 100 nM
Compound 4 gave a limit, no number (the forecaster's own chance of this, stated with the estimate: 50%); middle value at least 3.0-fold (0.47 log units) from the limit.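

In this assay compound 4 gives < 100 nM, which is a limit and not a number: the limit of < 100 nM in this assay, at which 2 of the 4 values shown sit.

Within the data shown here, the carbon on the shared core can therefore carry a group with no nitrogen, 2-carboxyethyl, and still show an at least 10-fold lower number from compound 1 to compound 4 (1.00 log units; beyond the scatter), so an N-alkylated amide is not the only group here that stands clear of the unsubstituted carbamoyl. The steps from compound 2 and compound 3 to compound 4 cannot be read.

From the compounds shown here alone, how compound 4 truly ranks against those two remains open. So does the effect of a shorter or longer carboxylic acid chain, its methyl ester, or an amine at this position.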